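The source may hold more compounds than are shown below. What is called first, only, known or untested is meant among the compounds shown, and "the series" means these compounds.

Compound 1 `CCCCN(CC)Cc1c(C(F)(F)F)nc2n(-c3c(C)cc(C)cc3C)c(Cl)cn12` gives 78 nM in an assay on cells for displacement of a labelled ligand from corticotropin-releasing factor receptor 1 (Homo sapiens), with a stated time of 100 min; on this read-out higher numbers stand for weaker inhibition and lower numbers for stronger inhibition
Compound 2 `CCCCN(C)Cc1c(C(F)(F)F)nc2n(-c3c(C)cc(C)cc3C)c(Cl)cn12` gives 310 nM in this assay
Compound 3 `Cc1cc(C)c(-n2c(Cl)cn3c(CN(C)Cc4ccccc4)c(C(F)(F)F)nc23)c(C)c1` gives 160 nM in this assay

Compound 3 sits between the other two on these numbers: the step of a 2.1-fold higher number from compound 1 to compound 3 (0.31 log units; beyond the scatter) lies beyond the scatter, while a 1.9-fold lower number from compound 2 to compound 3 (0.29 log units; within the scatter) lies within it. Compound 4 `Cc1cc(C)c(-n2c(Cl)cn3c(CN4CCCC(C)C4)c(C(F)(F)F)nc23)c(C)c1` differs from compound 3 by 3-methylpiperidin-1-yl in place of benzyl(methyl)amino on a saturated chain carbon bound to an aromatic carbon. The measured steps that bear on this site are a 2.1-fold higher number from compound 1 to compound 3 (0.31 log units; beyond the scatter) and a 4.0-fold higher number from compound 1 to compound 2 (0.60 log units; beyond the scatter), both modest, and a 1.9-fold lower number from compound 2 to compound 3 (0.29 log units; within the scatter). For the measured compounds named here, no measured step brings a saturated ring to this position, so the direction is uncertain; a modest change at most is expected for compound 4, a 1.1-fold lower number from compound 3 to compound 4 (0.03 log units; within the scatter). Compound 4 is therefore estimated at 150 nM, with a range from 50 nM to 500 nM.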

Compound 4, inhibition constant: 5800 nM
Compound 4: the middle estimate sits 39-fold (1.59 log units) below what was measured; the measured number lies above the stated range.
By their numbers in this assay, from the lowest: compound 1; then compounds 3 and 2 (each within the scatter of the next); then compound 4.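

In this assay the change to 3-methylpiperidin-1-yl gives large steps from every open-chain amine shown: a 36-fold higher number from compound 3 to compound 4 (1.56 log units; beyond the scatter) and a 19-fold higher number from compound 2 to compound 4 (1.27 log units; beyond the scatter) and a 74-fold higher number from compound 1 to compound 4 (1.87 log units; beyond the scatter). For the compounds shown here, the earlier steps at this place, on a saturated chain carbon bound to an aromatic carbon, were modest at most, so this is the first sign that the read-out here can shift strongly. Nothing given here explains the shift. The compounds shown leave open whether the ring or its methyl accounts for it; unsubstituted piperidin-1-yl or morpholin-4-yl would bear on that.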